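A few compounds are considered here, and "the series" means these few. Any claim that something is new, unique, unknown or untested is made for them only; others in the source may bear on it.

Measured in a functional assay on ZR-75-1 cells (Homo sapiens) for inhibition, read by sulforhodamine B assay; a higher number here means a weaker inhibitor of growth, a lower number a stronger inhibitor of growth:
- compound 1 `Cc1ccc2[nH]c(-c3ccc(-c4ccc(-c5ccccc5)cc4)cc3)nc2c1`: 27400 nM
- compound 2 `Cc1ccc2[nH]c(-c3ccc(-c4ccc(-c5ccc(F)cc5)cc4)cc3)nc2c1`: 35000 nM
- compound 3 `Cc1ccc2[nH]c(-c3ccc(-c4ccc(-c5ccc(C(F)(F)F)cc5)cc4)cc3)nc2c1`: 2410 nM

Of these three, compound 3 has the lowest number, 2410 nM, and its steps to both others lie beyond the scatter. Compound 4 `Cc1ccc2[nH]c(-c3ccc(-c4ccc(-c5ccc(O)cc5)cc4)cc3)nc2c1` has hydroxy in place of trifluoromethyl on an aromatic carbon, para to a large group: hydroxy in place of trifluoromethyl on an aromatic carbon.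

Among the measured compounds shown here, three measured steps bear on this change. Trifluoromethyl gave large steps in both comparisons: an 11-fold lower number from compound 1 to compound 3 (1.06 log units; beyond the scatter) and a 15-fold lower number from compound 2 to compound 3 (1.16 log units; beyond the scatter). Fluoro in place of hydrogen gave only a 1.3-fold higher number from compound 1 to compound 2 (0.11 log units; within the scatter). For the measured compounds named here, no measured compound carries hydroxy, so its own contribution is unknown, and the removal of trifluoromethyl is the only guide. On that basis, the number is expected to rise back towards those of compound 1 and compound 2, perhaps not fully. The expected step is a 6.2-fold higher number from compound 3 to compound 4 (0.79 log units; beyond the scatter), towards a higher number and so a weaker inhibitor of growth. For compound 4 the estimate is 15000 nM, with an expected range of 4000 nM to 50000 nM.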

Compound 4, concentration for 50% growth inhibition: 18200 nM
Estimate against measurement, compound 4: 1.2-fold (0.08 log units) below; the measured number falls inside the stated range.
By their numbers in this assay, from the lowest: compound 3; then compounds 4, 1 and 2 (each within the scatter of the next).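

In this assay, the gain seen with trifluoromethyl did not carry over to hydroxy at this position (a 7.6-fold higher number from compound 3 to compound 4 (0.88 log units; beyond the scatter)). Hydroxy instead left the number level with those of the compounds carrying hydrogen (a 1.5-fold lower number from compound 1 to compound 4 (0.18 log units; within the scatter)) and fluoro (a 1.9-fold lower number from compound 2 to compound 4 (0.28 log units; within the scatter)), both steps lying within the scatter, so among the four compounds shown, only the one with trifluoromethyl stands apart at this position. Nothing given here accounts for this difference between trifluoromethyl and the other three substituents.

Going by these compounds, whether the lower number is unique to trifluoromethyl remains open, as no other group that could test this, such as methoxy, chloro, nitrile, an amine or a carboxylic acid, appears at this position. On these data alone, it is also open whether trifluoromethyl would give a similar step if placed elsewhere on the shared core.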